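From Methyl to Nitro on the Aromatic Ring

The compounds below may be only part of what the source reports. "The series", "measured", "known", "first", "only" and "open" are said of these compounds alone.

Compound 1 `COc1ccc(/C=C/C(=O)/C=C/C2=C(C)CCCC2(C)C)cc1`: 19600 nM
Compound 2 `CC1=C(/C=C/C(=O)/C=C/c2ccc(C)cc2)C(C)(C)CCC1`: 23800 nM

Of the compounds shown here, two sharing one core have been measured in a functional assay on MCF7 cells (Homo sapiens) for cytotoxicity, read by sulforhodamine B assay, with a stated time of 48 h; on this read-out lower numbers stand for stronger inhibition and higher numbers for weaker inhibition. Compound 1 carries a methoxy on the aromatic ring and gives 19600 nM; compound 2 carries a methyl there and gives 23800 nM. Between them the change is a methyl in place of methoxy on an aromatic carbon: a 1.2-fold higher number from compound 1 to compound 2 (0.08 log units; within the scatter). For the measured compounds named here, compound 2 therefore stands at the higher of the two numbers, yet its only neighbour, compound 1, lies within the scatter of it, so no order between the two can be claimed.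

Compound 3 `CC1=C(/C=C/C(=O)/C=C/c2ccc([N+](=O)[O-])cc2)C(C)(C)CCC1` differs from compound 2 in one place: nitro in place of methyl on an aromatic carbon. Going by the values given here, only one measured step bears on this change, and only loosely: the exchange of one small group for another on the same aromatic carbon, from compound 1 to compound 2, stayed within the scatter. Among the compounds with values here, no measured step involves a nitro group, so nothing in the data points to a large move. On this basis the step of a 1.2-fold lower number from compound 2 to compound 3 (0.08 log units; within the scatter) is expected to remain within the scatter. Compound 3 is estimated to give 20000 nM in this assay, with a range from 8000 nM to 50000 nM.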

Compound 3, half-maximal inhibitory concentration: 5500 nM
For compound 3 the middle estimate is 3.6-fold (0.56 log units) above the measured one, outside the stated range (below it).
By their numbers in this assay, from the lowest: compound 3; then compounds 1 and 2 (each within the scatter of the next).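

In this assay, the aromatic carbon para to a large group proves sensitive to what it carries: nitro in place of methyl gives a 4.3-fold lower number from compound 2 to compound 3 (0.64 log units; beyond the scatter), and nitro in place of methoxy gives a 3.6-fold lower number from compound 1 to compound 3 (0.55 log units; beyond the scatter), whereas the exchange of methoxy for methyl, a 1.2-fold higher number from compound 1 to compound 2 (0.08 log units; within the scatter), moved nothing that can be read. Both nitro steps are modest, but they lie beyond the scatter and point the same way, so the substituent at this position can change the cytotoxicity read-out, and nitro separates compound 3 from compounds 1 and 2, which cannot be ordered against each other. Nothing available accounts for this difference, and the numbers record only that it occurs.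

The compounds shown leave open whether the shift is particular to nitro or would also appear with a nitrile, a trifluoromethyl, an amine or a carboxylic acid on this carbon. They also leave open whether nitro would give a similar step on another carbon of the same aromatic ring.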